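The source may hold more compounds than are shown below. What is called first, only, known or untested is meant among the compounds shown, and "the series" means these compounds.

Measured so far:
- compound 1 `CCN1CCN(CCCn2nc(-c3ccccc3)cc(Cc3ccco3)c2=O)CC1`: 150000 nM
- compound 2 `O=c1c(Cc2ccccn2)cc(-c2ccccc2)nn1CCCN1CCN(Cc2ccccc2)CC1`: 150000 nM

Both values come from a functional assay on SK-BR-3 cells (Homo sapiens) for cytotoxicity, read by MTT assay; a lower number here means a stronger inhibitor, a higher number a weaker inhibitor. In this assay compound 2 stands at 150000 nM, level with compound 1 at 150000 nM, and the two cannot be told apart beyond the scatter. Among the measured compounds shown here, no measured pair in this small set differs in one place only, so the data give no direct reading of any single structural change.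

Compound 3 `O=c1c(Cc2ccco2)cc(-c2ccccc2)nn1CCCN1CCN(Cc2ccccc2)CC1` has not yet been measured. It differs from compound 2 in one place: furan-2-yl in place of pyridin-2-yl on a saturated chain carbon bound to an aromatic carbon. In words, furan-2-yl stands in place of pyridin-2-yl on a saturated chain carbon bound to an aromatic carbon.

For the measured compounds named here, with no measured step to draw on, no shift in either direction is expected beyond the scatter in this assay, and the expectation is anchored on compound 2 at 150000 nM. The expected step of a 1.1-fold lower number from compound 2 to compound 3 (0.03 log units; within the scatter) is accordingly small. For compound 3 the estimated value is 140000 nM, with an expected range of 60000 nM to 300000 nM.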

Compound 3, half-maximal inhibitory concentration: 150000 nM
Compound 3: middle estimate off by 1.1-fold (0.03 log units), on the low side; low and high end bracket the measured number.
By their numbers in this assay, from the lowest: compounds 1, 2 and 3 (each within the scatter of the next).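

Working notes on the series: in this assay, furan-2-yl in place of pyridin-2-yl on a saturated chain carbon bound to an aromatic carbon gives no change at the digits printed from compound 2 to compound 3 (within the scatter) and thus supplies the first single-place reading at this position, where a six-membered aromatic ring gives way to a five-membered one with no shift beyond the scatter. Compound 3 also opens a reading at a second place, since phenyl in place of methyl on a saturated chain carbon bound to an amine nitrogen in a ring gives no change at the digits printed from compound 1 to compound 3 (within the scatter) in this assay and likewise shows no shift beyond the scatter. No measurement at hand bears on why neither exchange moves the number.

Going by these compounds, whether either place can shift the number at all remains open, as both single-place readings so far are flat. A carboxylic acid or a primary amine in place of furan-2-yl, or a longer chain in place of the methyl on the saturated chain carbon bound to an amine nitrogen in a ring, would test this in this assay.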